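Swapping a Chloropyridine for an Oxazole on the Shared Core

A few compounds are considered here, and "the series" means these few. Any claim that something is new, unique, unknown or untested is made for them only; others in the source may bear on it.

Compound 1 `O=C(O)CCn1c(=O)oc2cc(OCc3ccccc3)c(Cl)cc21`: 1580 nM
Compound 2 `O=C(O)CCn1c(=O)oc2cc(OCC3CC3)c(Cl)cc21`: 1580 nM
Compound 3 `C[C@@H](Oc1cc2oc(=O)n(CCC(=O)O)c2cc1Cl)c1ccc(Cl)cn1`: 100 nM

In an assay on HEK293 cells for inhibition of kynurenine 3-monooxygenase (Homo sapiens), read by LC-MS, with a stated time of 20 h (on this read-out lower numbers stand for stronger inhibition and higher numbers for weaker inhibition), compound 3 stands lowest of the three measured compounds; compound 1 and compound 2 both sit well beyond the scatter above it, by the same margin. Compound 4 `C[C@@H](Oc1cc2oc(=O)n(CCC(=O)O)c2cc1Cl)c1ncco1` differs from compound 3 by 1,3-oxazol-2-yl in place of 5-chloropyridin-2-yl on a saturated chain carbon bound to an oxygen on an aromatic ring and a saturated chain carbon. Among the measured compounds shown here, the only measured step at this same place, no change at the digits printed from compound 1 to compound 2 (within the scatter), exchanged one ring for a quite different one without moving the number. That step suggests the group on this carbon is tolerant to exchange, but it was made on a weaker pair, and the ring that enters here is smaller than the one that leaves. Compound 4 is therefore expected to be modestly weaker, estimated at 300 nM with a range of 100 nM to 1000 nM, a step of a 3.0-fold higher number from compound 3 to compound 4 (0.48 log units; beyond the scatter).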

Compound 4, half-maximal inhibitory concentration: 7940 nM
For compound 4 the middle estimate is 26-fold (1.42 log units) below the measured one, outside the stated range (above it).
By their numbers in this assay, from the lowest: compound 3; then compounds 1 and 2 (each within the scatter of the next); then compound 4.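

In this assay the exchange of 5-chloropyridin-2-yl for 1,3-oxazol-2-yl gives a 79-fold higher number from compound 3 to compound 4 (1.90 log units; beyond the scatter) on this chain carbon, so the ring held here can matter greatly, which the flat step between compound 1 and compound 2 did not reveal. The new ring also trails the earlier groups on that oxygen, with a 5.0-fold higher number from compound 2 to compound 4 (0.70 log units; beyond the scatter) and a 5.0-fold higher number from compound 1 to compound 4 (0.70 log units; beyond the scatter) as the gaps. Nothing measured here gives a reason for the loss. Still open, as far as these compounds go, is whether the loss follows the chlorine or the ring itself, and a pyridin-2-yl group without chlorine would separate the two.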